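The source may report more compounds than this note shows. Statements on the series, on what has been measured and on what is new or still open speak of the compounds shown alone.

Compound 1 `CCCCCCCCn1nc(-c2cccnc2)c2ccccc2c1=O`: 99%
Compound 2 `O=c1c2ccccc2c(-c2cccnc2)nn1CCSc1nccs1`: 97%

In an assay on isolated protein (Oryctolagus cuniculus) with Thromboxane-A synthase (Homo sapiens) as the target, tested at 1 uM (a lower number here means less inhibition, a higher number more inhibition at the concentration tested (going by the name of the read-out)), compound 1 gives 99% and compound 2 gives 97%. Compound 2 stands lowest of the two numbers, but its nearest neighbour, compound 1, sits only a number 2 percentage points lower from compound 1 to compound 2 (within the scatter), so the two cannot be ordered. Compound 3 `O=C(O)c1ccc(Cn2nc(-c3cccnc3)c3ccccc3c2=O)cc1` has not been measured; it differs from compound 2 by 4-carboxyphenyl in place of ((1,3-thiazol-2-yl)sulfanyl)methyl on a saturated chain carbon bound to an aromatic nitrogen. Among the compounds with values here, the one measured step, a number 2 percentage points lower from compound 1 to compound 2 (within the scatter), concerns a different group at the same chain region and was within the scatter, so it bears on the new change only loosely. Both measured compounds lie near the top of the scale, which leaves little room upward. Compound 3 is therefore expected to show a number 9 percentage points lower from compound 2 to compound 3 (within the scatter), and its inhibition is estimated at 88%, in the range 65% to 99%.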

Compound 3, a percentage reported as inhibition, at one concentration (the size of the read-out at that concentration, not a potency): 64%
Beside the measured number, compound 3's estimate is 24 percentage points above it; measured number outside the range, below it.
By their numbers in this assay, from the lowest: compound 3; then compounds 2 and 1 (each within the scatter of the next).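

Within the data shown here, the place on a saturated chain carbon bound to an aromatic nitrogen does not accept every group alike: putting 4-carboxyphenyl in place of ((1,3-thiazol-2-yl)sulfanyl)methyl gives a number 33 percentage points lower from compound 2 to compound 3 (beyond the scatter) in this assay, the first step here beyond the scatter. The change from heptyl reads much the same, with a number 35 percentage points lower from compound 1 to compound 3 (beyond the scatter) in this assay, so the closeness of the first two compounds did not hold for every group at this place. Nothing available gives a reason for this drop in inhibition.

From the compounds shown here alone, what a plain phenyl, a methyl ester of the acid or an amine would give at this place stays open, and with it whether the step belongs to the carboxylic acid or to the ring that carries it. Also open, going by these compounds, is how a longer chain ending in the same carboxylic acid would read in this assay at this place.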